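Replacing a Methoxycarbonyl Amide by a Butyramide

The source may hold more compounds than are shown below. What is called first, only, known or untested is meant among the compounds shown, and "the series" means these compounds.

Three measured compounds share one core and differ only at the nitrogen on the aromatic ring. Compound 1 `COc1cc(/C=C/C(=O)c2cccc(N)c2)ccc1O` carries a free amine there, and in a functional assay on HUVEC cells (Homo sapiens) for inhibition, tested at 10 ug/mL (on this read-out higher numbers stand for a stronger effect at the one concentration tested and lower numbers for a weaker effect), compound 1 gives 90%. Compound 2 `COc1cc(/C=C/C(=O)c2cccc(NC(=O)C(C)C)c2)ccc1O` bears isopropylcarbonyl in place of hydrogen on that nitrogen and gives 56%. Compound 3 `COC(=O)C(=O)Nc1cccc(C(=O)/C=C/c2ccc(O)c(OC)c2)c1` bears (methoxycarbonyl)carbonyl on the same nitrogen and gives 43%, the lowest of the three numbers. The steps are a number 34 percentage points lower from compound 1 to compound 2 (beyond the scatter) and a number 47 percentage points lower from compound 1 to compound 3 (beyond the scatter), and between the two acylated compounds a number 13 percentage points lower from compound 2 to compound 3 (beyond the scatter).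

Compound 4 `CCCC(=O)Nc1cccc(C(=O)/C=C/c2ccc(O)c(OC)c2)c1` differs from compound 3 by propyl in place of methoxycarbonyl on a carbonyl carbon. The step that bears most directly on this change is a number 13 percentage points lower from compound 2 to compound 3 (beyond the scatter), which went from isopropyl to methoxycarbonyl on the carbonyl carbon; the present change runs the other way, to a group closely akin to isopropyl. Compound 4 is therefore expected to land near compound 2 rather than near compound 1, since both acylated compounds sit well under the free amine. The expected step is a number 12 percentage points higher from compound 3 to compound 4 (beyond the scatter). Compound 4 is estimated to give 55%, within a range from 40% to 70%.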

Compound 4, a percentage reported as inhibition, at one concentration (the size of the read-out at that concentration, not a potency): 87%
Compound 4: middle estimate off by 32 percentage points, on the low side, and the stated range ends below it.
By their numbers in this assay, from the lowest: compound 3; then compound 2; then compounds 4 and 1 (each within the scatter of the next).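

Acylation of the nitrogen on the aromatic ring does not by itself lower the number in this assay, since propylcarbonyl in place of hydrogen gives a number 3 percentage points lower from compound 1 to compound 4 (within the scatter) and leaves the amide level with the free amine, so the drop seen with the two earlier acylated compounds belongs to the particular groups they carry. What sits on the carbonyl carbon decides the outcome, as shown by a number 44 percentage points higher from compound 3 to compound 4 (beyond the scatter) on replacing methoxycarbonyl with propyl, and even the change from isopropyl to propyl, two small carbon chains, gives a number 31 percentage points higher from compound 2 to compound 4 (beyond the scatter) and so makes isopropyl a poor guide to propyl at this position. The data at hand give no reason for this sharp difference between the straight and the branched chain.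

The compounds shown leave open whether the high number survives with a shorter ethyl group, a longer pentyl chain or a cyclopropyl ring on the carbonyl carbon. They also leave open whether a sulfonamide on the same nitrogen would behave like the propyl amide or like the two lower acylated compounds.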